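Working notes on cytotoxicity: the step to compound 3

The source may report more compounds than this note shows. Statements on the series, on what has been measured and on what is new or still open speak of the compounds shown alone.

Measured so far:
compound 1 `COc1nc2ccc(Br)cc2cc1C(c1ccccc1)n1cc(-c2cccc(F)c2)nn1` with 14.6%
compound 2 `COc1nc2ccc(Br)cc2cc1C(c1ccccc1)n1cc(CO)nn1` with 4.65%

Two compounds of the shared core have been run in an ADME assay on PC-3 cells (Homo sapiens) for cytotoxicity, read by sulforhodamine B assay, with a stated time of 48 h, tested at 10 uM; on this read-out higher numbers stand for more inhibition at the one concentration tested (going by the name of the read-out) and lower numbers for less inhibition. Compound 1 gives 14.6% and stands highest of the two numbers, yet its nearest neighbour is compound 2, with the step of a number 10 percentage points lower from compound 1 to compound 2 (within the scatter), so the two sit within the scatter of each other and no order between them is claimed. Going by the values given here, the single measured step, hydroxymethyl in place of 3-fluorophenyl on an aromatic carbon, therefore shows no effect beyond the scatter.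

Compound 3 `CCOC(=O)c1cn(C(c2ccccc2)c2cc3cc(Br)ccc3nc2OC)nn1` is not yet measured. It differs from compound 1 by ethoxycarbonyl in place of 3-fluorophenyl on an aromatic carbon. Among the compounds with values here, the only step that bears on it is the one from compound 1 to compound 2, where another small group replaced the same 3-fluorophenyl and the number moved within the scatter. With so little to go on, no step beyond the scatter is expected in this assay for compound 3 either; the expected step from compound 1 is a number 6.6 percentage points lower from compound 1 to compound 3 (within the scatter). The estimate for compound 3 is 8%, with a range from -3% to 20%.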

Compound 3, a percentage reported as inhibition, at one concentration (the size of the read-out at that concentration, not a potency): 16.1%
Compound 3: the middle estimate sits 8.1 percentage points below what was measured; the measured number falls inside the stated range.
By their numbers in this assay, from the lowest: compounds 2, 1 and 3 (each within the scatter of the next, the first and the last beyond it).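

Going by these compounds alone, the group on this aromatic carbon of the five-membered aromatic ring with 3 nitrogen can now be seen to matter in this assay, since ethoxycarbonyl in place of hydroxymethyl gives a number 11.5 percentage points higher from compound 2 to compound 3 (beyond the scatter) and this is the first step beyond the scatter at this position, though only a modest one. Ethoxycarbonyl in place of 3-fluorophenyl gives a number 1.5 percentage points higher from compound 1 to compound 3 (within the scatter) in this series, so compound 1 lies within the scatter of both compound 2 and compound 3, and replacing 3-fluorophenyl with a group that has no ring shows no effect beyond the scatter in either case. Nothing available accounts for the gap between the two groups without a ring.

The three compounds leave open whether the gap follows the ester as a whole or only part of it, which a carboxylic acid, a primary amide or a longer alkyl ester at this carbon would help to separate. An aminomethyl group at the same carbon would extend the comparison with hydroxymethyl, and the single tested concentration leaves potency across the series open.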